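This account rests on a few compounds, and the source may have more. Where it says the series, first, only, none or still open, it means among the compounds named here.

In a functional assay on Jurkat cells (Homo sapiens) (on this read-out lower numbers stand for stronger inhibition and higher numbers for weaker inhibition), compound 1 (`CC(C)[C@H](NC(=O)COc1cccc2ccccc12)C(=O)N[C@@H](CC(=O)O)C(=O)COc1ccc(C(F)(F)F)cc1`) gives only a limit, > 100000 nM. Compound 2 (`CC(C)[C@H](NC(=O)COc1cccc2ccccc12)C(=O)N[C@@H](CC(=O)O)C(=O)COc1cccc(F)c1`) also gives only a limit, > 100000 nM. Compound 3 (`CC(C)[C@H](NC(=O)COc1cccc2ccccc12)C(=O)N[C@@H](CC(=O)O)C(=O)COc1ccc(F)cc1`) likewise gives only a limit, > 100000 nM. Compound 3 therefore has no numerical position in the series and stands with the other two at the limit of > 100000 nM in this assay, at which 3 of the 3 values shown sit.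

Compound 4 (`CC(C)[C@H](NC(=O)COc1cccc2ccccc12)C(=O)N[C@@H](CC(=O)O)C(=O)COc1cc(F)ccc1F`) keeps the core of compound 3 and carries 2,5-difluorophenyl in place of 4-fluorophenyl on an oxygen on a saturated carbon.

The measured steps that bear on this change are a step that the two limits leave unreadable from compound 1 to compound 2, a step that the two limits leave unreadable from compound 1 to compound 3 and a step that the two limits leave unreadable from compound 2 to compound 3. Among the measured compounds shown here, all three concern the same group on the same oxygen, yet none has a readable size, so they offer no measured step to carry over and no direction to follow. The three changes of this group have so far left every compound at the limit, and none goes against that pattern. The expectation for compound 4 therefore rests on compound 3, whose > 100000 nM is a limit, and on the two other compounds, and a reported limit is the likeliest outcome in this assay.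

The expected change is a number no higher from compound 3 to compound 4 (the limit leaves the size open), with no direction that the data can support. Compound 4 is estimated at 100000 nM, with an expected range from 20000 nM to 200000 nM.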

Compound 4, half-maximal inhibitory concentration: > 100000 nM
Compound 4 gave a limit, no number (the forecaster's own chance of this, stated with the estimate: 75%); the middle value lies on the limit itself.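

No new step can be read: compound 4 gives only a limit in this assay, > 100000 nM, so its comparisons with compound 1, compound 2 and compound 3 have no readable size. The compounds shown leave open how far each lies past that limit and whether changing the group on this oxygen alters inhibition at all: the limit of > 100000 nM in this assay, at which 4 of the 4 values shown sit.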